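The compounds below may be only part of what the source reports. "The series", "measured", "known", "first", "only" and "open" are said of these compounds alone.

Compound 1 `COc1ccc(C(=O)/C=C/c2cn(-c3ccccc3)nc2-c2ccsc2)cc1OC` was examined in a functional assay on HCT-116 cells (Homo sapiens) for inhibition, read by sulforhodamine B assay, with a stated time of 72 h (a higher number here means a weaker inhibitor, a lower number a stronger inhibitor), where compound 1 gives 1600 nM. Compound 2 `COc1ccc(OC)c(C(=O)/C=C/c2cn(-c3ccccc3)nc2-c2ccsc2)c1` carries 2,5-dimethoxyphenyl in place of 3,4-dimethoxyphenyl on a carbonyl carbon; in this assay compound 2 gives 3400 nM, a step of a 2.1-fold higher number from compound 1 to compound 2 (0.33 log units; beyond the scatter). Compound 3 `COc1ccc(C(=O)/C=C/c2cn(-c3ccccc3)nc2-c2cccnc2)cc1OC` differs from compound 1 by pyridin-3-yl in place of thiophen-3-yl on an aromatic carbon, and in this assay compound 3 gives 4300 nM, which is a 2.7-fold higher number from compound 1 to compound 3 (0.43 log units; beyond the scatter). The values of compound 2 and compound 3 lie within the usual scatter of each other, so nothing separates them.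

Compound 4 `COc1ccc(OC)c(C(=O)/C=C/c2cn(-c3ccccc3)nc2-c2cccnc2)c1` has not yet been measured. It differs from compound 3 by 2,5-dimethoxyphenyl in place of 3,4-dimethoxyphenyl on a carbonyl carbon, the same change that separates compound 1 from compound 2, now made on the core of compound 3 rather than the core of compound 1. Because a 2.1-fold higher number from compound 1 to compound 2 (0.33 log units; beyond the scatter) was modest yet beyond the scatter, a step of about the same size is expected here, a 2.1-fold higher number from compound 3 to compound 4 (0.32 log units; beyond the scatter), though it rests on a single earlier instance, so the range is kept wide. Compound 4 is therefore expected to give 9000 nM in this assay, with a likely range from 4000 nM to 20000 nM.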

Compound 4, half-maximal inhibitory concentration: 1000 nM
The estimate for compound 4 lay 9.0-fold (0.95 log units) above the measured number, outside the stated range (below it).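

In this assay, 2,5-dimethoxyphenyl in place of 3,4-dimethoxyphenyl on the carbonyl carbon gave a 4.3-fold lower number from compound 3 to compound 4 (0.63 log units; beyond the scatter), so this change did not keep its direction when carried from one core to the other: the same change on two cores in this assay, a 2.1-fold higher number (0.33 log units; beyond the scatter) from compound 1 to compound 2 and a 4.3-fold lower number (0.63 log units; beyond the scatter) from compound 3 to compound 4, 9.1-fold (0.96 log units) apart, beyond the scatter of two such steps. Likewise, pyridin-3-yl in place of thiophen-3-yl gave a 3.4-fold lower number from compound 2 to compound 4 (0.53 log units; beyond the scatter), which reverses the direction of the same change on the other dimethoxyphenyl arrangement: the same change on two cores in this assay, a 2.7-fold higher number (0.43 log units; beyond the scatter) from compound 1 to compound 3 and a 3.4-fold lower number (0.53 log units; beyond the scatter) from compound 2 to compound 4, 9.1-fold (0.96 log units) apart, beyond the scatter of two such steps. Within these four compounds, neither change can be carried across as a fixed step, but the data do not show why, and with only two instances of each change they establish no rule for the wider series.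

The compounds shown leave open whether this dependence between the two positions persists when the thiophen-3-yl or pyridin-3-yl group gives way to an amine or a carboxylic acid. They also leave open whether it persists when a methoxy group is replaced by a longer chain such as butoxy.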